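Swapping a Naphthalene Amide for a Dimethylphenyl Amide

This account rests on a few compounds, and the source may have more. Where it says the series, first, only, none or still open, it means among the compounds named here.

Measured compounds:
compound 1 `O=C(CCCCCN(CC(=O)NC1CCCCC1)C(=O)c1cccc2ccccc12)NO` gives 260 nM in a functional assay on A2780 cells (Homo sapiens) for cytotoxicity, read by MTT assay, with a stated time of 72 h; on this read-out lower numbers stand for stronger inhibition and higher numbers for weaker inhibition
compound 2 `CC(C)(C)NC(=O)C(C)(C)N(CCCCCC(=O)NO)C(=O)c1ccccc1` gives 207000 nM in this assay

Among the measured compounds shown here, compound 1 holds the lower of the two numbers; compound 2 lies far above it, well beyond the scatter, though the two differ in more than one place, so no single step is known. Compound 3 `Cc1cc(C)cc(C(=O)N(CCCCCC(=O)NO)CC(=O)NC2CCCCC2)c1` is not yet measured. It differs from compound 1 by 3,5-dimethylphenyl in place of naphthalen-1-yl on a carbonyl carbon. For the measured compounds named here, no measured pair tells what this change does. A modest weakening step is expected, estimated as a 2.3-fold higher number from compound 1 to compound 3 (0.36 log units; beyond the scatter). For compound 3 the expected value is 600 nM, with a range from 150 nM to 3000 nM.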

Compound 3, half-maximal inhibitory concentration: 160 nM
For compound 3 the middle estimate is 3.8-fold (0.57 log units) above the measured one; measured number inside the range.
By their numbers in this assay, from the lowest: compounds 3 and 1 (each within the scatter of the next); then compound 2.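

Replacing naphthalen-1-yl with 3,5-dimethylphenyl on the carbonyl carbon gives a 1.6-fold lower number from compound 1 to compound 3 (0.21 log units; within the scatter) in this assay and shows that, in this pair, this position holds one aromatic ring as well as two without a change that stands clear of the scatter. Nothing at hand bears on why this is so. Still open, as far as these compounds go, is how this position would respond to a carboxylic acid or an amine on the aromatic ring. A pyridine ring in the same place is equally untested by the compounds shown.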